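The source may hold more compounds than are shown below. What is called first, only, known or untested is meant among the compounds shown, and "the series" means these compounds.

Two measured compounds lead up to this step. In a functional assay, with a stated time of 6 min (a lower number here means a stronger inhibitor, a higher number a weaker inhibitor), compound 1 (`Nc1ncccc1/N=C/c1ccnc(NC(=O)C2CC2)c1`) gives 3880 nM and compound 2 (`Nc1ncc(-c2ccccc2)cc1/N=C/c1ccnc(NC(=O)C2CC2)c1`) gives 7300 nM, so the two lie within the usual scatter of each other and compound 2 stands level with compound 1 on these numbers. The next compound, compound 3 (`Nc1ncc(-c2ccncc2)cc1/N=C/c1ccnc(NC(=O)C2CC2)c1`), carries pyridin-4-yl in place of phenyl on an aromatic carbon. Going by the values given here, only one measured step bears on this position: phenyl in place of hydrogen there gave a 1.9-fold higher number from compound 1 to compound 2 (0.27 log units; within the scatter), a change that does not stand out from the scatter. Among the compounds with values here, no measured compound yet has a ring nitrogen in this group, so no step beyond the scatter is expected in this assay and neither direction can be firmly favoured. The estimated step is small, a 1.2-fold lower number from compound 2 to compound 3 (0.09 log units; within the scatter), and the range around it is wide. Compound 3 is expected at about 6000 nM, with an estimated range from 2000 nM to 18000 nM.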

Compound 3, half-maximal inhibitory concentration: 3440 nM
For compound 3 the middle estimate is 1.7-fold (0.24 log units) above the measured one; the measured number falls inside the stated range.
By their numbers in this assay, from the lowest: compounds 3, 1 and 2 (each within the scatter of the next, the first and the last beyond it).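

In this assay, going by these compounds alone, pyridin-4-yl in place of phenyl gives a 2.1-fold lower number from compound 2 to compound 3 (0.33 log units; beyond the scatter), the first step at this position to clear the scatter, though only modestly. A single ring nitrogen in this group can therefore be told apart from the all-carbon ring, which the phenyl step from hydrogen could not show. Set against hydrogen, pyridin-4-yl gives a 1.1-fold lower number from compound 1 to compound 3 (0.05 log units; within the scatter), so this ring offers no measurable gain over the bare position, and nothing available here explains the difference between the two rings.

As far as these compounds go, what pyridin-3-yl, with the ring nitrogen elsewhere in the ring, would give stays open. So does the effect of a group of a different kind at this position, such as an amine, a carboxylic acid or a longer chain.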